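Nitro-to-Amino Exchange on a Benzyl Oxadiazolone Series

This account rests on a few compounds, and the source may have more. Where it says the series, first, only, none or still open, it means among the compounds named here.

Measured compounds:
compound 1, `COc1nn(Cc2ccccc2[N+](=O)[O-])c(=O)o1`, 36%
compound 2, `COc1nn(Cc2ccccc2N)c(=O)o1`, 8%
compound 3, `CCOc1nn(Cc2cccc([N+](=O)[O-])c2)c(=O)o1`, reported as "not active" (no number reported), with no single number

The study tests these compounds in an assay on COS-7 cells for inhibition of Fatty-acid amide hydrolase 1 (Homo sapiens), read by scintillation counting, with a stated time of 10 min, tested at 10 uM; a lower number here means less inhibition, a higher number more inhibition at the concentration tested (going by the name of the read-out). Compound 1 gives 36% in this assay. Compound 2 differs from it by amino in place of nitro on an aromatic carbon, and the step of a number 28 percentage points lower from compound 1 to compound 2 (beyond the scatter). Compound 3, carrying a larger alkoxy group, is reported as "not active" (no number reported) in this assay, with no single number; the difference between the core of compound 3 and the core of compound 1 is not broken down here. Compound 4, `CCOc1nn(Cc2cccc(N)c2)c(=O)o1`, differs from compound 3 by amino in place of nitro on an aromatic carbon. This is the same kind of change as that from compound 1 to compound 2, but the place differs: in compound 1 the group sits ortho to a group of 9 heavy atoms, whereas in compound 3 it sits meta to a large group. Since compound 3 is reported as "not active" (no number reported) in this assay, and the same kind of change lowered the inhibition number from compound 1 to compound 2, compound 4 is expected to show a low inhibition number, estimated at 3%, between 0% and 15%.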

Compound 4, a percentage reported as inhibition, at one concentration (the size of the read-out at that concentration, not a potency): 10%
The estimate for compound 4 lay 7 percentage points below the measured number; measured number inside the range.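

Within the data shown here, compound 3 carries no number, and so no step to compound 4 can be read. The compounds shown leave open whether exchanging nitro for amino acts alike in compound 3 and compound 1. Nothing here speaks to a cause.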